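A few compounds are considered here, and "the series" means these few. Any claim that something is new, unique, unknown or untested is made for them only; others in the source may bear on it.

Measured so far, with values from a functional assay on L02 cells (Homo sapiens) for inhibition, read by Griess assay, with stated times of 1 h and 24 h (a higher number here means a weaker inhibitor, a lower number a stronger inhibitor), as follows:
compound 1 `CCCc1nn(C)c2c(NCc3ccc(F)cc3)nc(/C=C/c3ccc[n+]([O-])c3)nc12` gives < 40000 nM (a limit)
compound 2 `CCCc1nn(C)c2c(NC3CC3)nc(CCc3cccnc3)nc12` gives 564000 nM (a number)

Among the compounds with values here, compound 2 with 564000 nM holds the only actual number so far, so no measured step can place it against a neighbour. Compound 1 with < 40000 nM is a limit, not a number.

Compound 3 `CCCc1nn(C)c2c(NCc3ccc(F)cc3)nc(CCc3cccnc3)nc12` is reached from compound 2 by a single change, with 4-fluorobenzyl in place of cyclopropyl on a nitrogen on an aromatic ring as the count of what differs: 4-fluorobenzyl in place of cyclopropyl on a nitrogen on an aromatic ring. Within the data shown here, no measured step covers this change. Among the measured compounds shown here, the only guide is compound 1, which also carries 4-fluorobenzyl and whose < 40000 nM is a limit. On that single indication, a move toward a stronger inhibitor is expected in this assay, with a 19-fold lower number from compound 2 to compound 3 (1.27 log units; beyond the scatter) as the estimated step, well beyond the usual scatter but of uncertain size. A report of a limit alone is also possible. For compound 3 the estimated value is 30000 nM with 6000 nM to 150000 nM as the expected range.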

Compound 3, half-maximal inhibitory concentration: < 40000 nM
Compound 3 ended at the assay's limit; the forecaster's own chance of this, stated with the estimate: 35%; the middle value is on the limit's open side.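

In this assay compound 3 gives < 40000 nM, which is a limit and not a number. Within the data shown here, replacing cyclopropyl with 4-fluorobenzyl on a nitrogen on an aromatic ring gives an at least 14-fold lower number from compound 2 to compound 3 (1.14 log units; beyond the scatter), the first readable step at this position, and it is large and beyond the scatter. The full size of this step remains unknown, because the reading for compound 3 stops at a limit shared with compound 1: the limit of < 40000 nM in this assay, at which 2 of the 3 values shown sit.

The step between compound 1 and compound 3 cannot be read, as both values are limits, so the change at the aromatic carbon remains unplaced. On these data alone, whether plain benzyl or cyclohexyl on the same nitrogen would give an actual number, and so separate the contribution of the fluorine from that of the aromatic ring, remains open.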